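Replacing 1-carbamoylpentyl with 2-oxooxolan-3-yl in compound 3

The compounds below may be only part of what the source reports. "The series", "measured", "known", "first", "only" and "open" are said of these compounds alone.

Measured in a physicochemical assay for lipophilicity, read by HPLC, at pH 7.5; on this read-out lower numbers stand for lower lipophilicity and higher numbers for higher lipophilicity:
- compound 1 `CCOc1ccccc1-c1ccc(-c2nc3cnccc3c(NC(C)C(=O)O)c2C#N)cc1`: 2.1
- compound 2 `CCOc1ccccc1-c1ccc(-c2nc3cnccc3c(C[C@H](C)C(=O)O)c2C#N)cc1`: 2.2
- compound 3 `CCCCC(Nc1c(C#N)c(-c2ccc(-c3ccccc3OCC)cc2)nc2cnccc12)C(N)=O`: 3.6

The highest of these three numbers belongs to compound 3. The smaller gap to it is a number 1.40 log units higher from compound 2 to compound 3 (beyond the scatter), and the wider one is a number 1.50 log units higher from compound 1 to compound 3 (beyond the scatter). Both are large.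

The next structure is compound 4 `CCOc1ccccc1-c1ccc(-c2nc3cnccc3c(N[C@@H]3CCOC3=O)c2C#N)cc1`, in which 2-oxooxolan-3-yl stands in place of 1-carbamoylpentyl on a nitrogen on an aromatic ring: 2-oxooxolan-3-yl in place of 1-carbamoylpentyl on a nitrogen on an aromatic ring.

For the measured compounds named here, no measured compound carries 2-oxooxolan-3-yl, so no step gauges this group directly. The closest guide is a number 1.50 log units higher from compound 1 to compound 3 (beyond the scatter), a change at the same place, which shows that a swap there can move the number a long way. The entering group has no net charge, and neither has the leaving one. A much smaller change in this assay is therefore expected, pointing down: a number 0.30 log units lower from compound 3 to compound 4 (within the scatter).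

For compound 4 the estimated value is 3.3, with an expected range from 2.8 to 3.8.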

Compound 4, distribution coefficient: 2.7
Estimate against measurement, compound 4: 0.60 log units above; measured number outside the range, below it.
By their numbers in this assay, from the lowest: compounds 1 and 2 (each within the scatter of the next); then compound 4; then compound 3.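

In this assay this position responds strongly even when the group that leaves and the group that enters both have no net charge: there is a number 0.90 log units lower from compound 3 to compound 4 (beyond the scatter) when 2-oxooxolan-3-yl, with its five-membered ring, replaces the open-chain 1-carbamoylpentyl. Compound 4 also separates from the two compounds that carry a carboxy group, with a number 0.60 log units higher from compound 1 to compound 4 (beyond the scatter) and a number 0.50 log units higher from compound 2 to compound 4 (beyond the scatter) as its two steps, so it sits between them and compound 3. Nothing available explains why the number moves in any of these steps.

The compounds shown leave open whether the ring itself matters or only the size of the group, and an open-chain methyl ester on the same nitrogen would help separate the two. The mirror-image form of the 2-oxooxolan-3-yl group also remains an open comparison.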